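Notes on aryl replacement in an antiproliferative series

The source may report more compounds than this note shows. Statements on the series, on what has been measured and on what is new or still open speak of the compounds shown alone.

Measured compounds, with their values in a functional assay on BJAB cells (Homo sapiens) for antiproliferative activity, with a stated time of 4 days; a lower number here means that less compound is needed, a higher number that more compound is needed for the effect:
- compound 1 `COc1cncc(-c2c(C)nn(-c3nc(-c4ccc(Cl)c(Cl)c4)c(SC(C)C)s3)c2C(=O)O)c1`: 21000 nM
- compound 2 `COc1ccccc1-c1c(C)nn(-c2nc(-c3ccc(Cl)c(Cl)c3)c(SC(C)C)s2)c1C(=O)O`: 14700 nM
- compound 3 `Cc1nn(-c2nc(-c3ccc(Cl)c(Cl)c3)c(SC(C)C)s2)c(C(=O)O)c1-c1cnn(C)c1`: 6800 nM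

Compound 3 holds the lowest number of the three; the steps to the other two are a 2.2-fold lower number from compound 2 to compound 3 (0.33 log units; beyond the scatter) and a 3.1-fold lower number from compound 1 to compound 3 (0.49 log units; beyond the scatter), both beyond the scatter. Compound 4 `Cc1cc(Cl)cc(-c2c(C)nn(-c3nc(-c4ccc(Cl)c(Cl)c4)c(SC(C)C)s3)c2C(=O)O)c1` has not been measured. Its change from compound 3 is 3-chloro-5-methylphenyl in place of 1-methyl-1H-pyrazol-4-yl on an aromatic carbon.

The measured steps that bear on it all vary the same position: a 1.4-fold lower number from compound 1 to compound 2 (0.15 log units; within the scatter), a 3.1-fold lower number from compound 1 to compound 3 (0.49 log units; beyond the scatter) and a 2.2-fold lower number from compound 2 to compound 3 (0.33 log units; beyond the scatter). The two six-membered rings, in compound 1 and compound 2, gave higher numbers than the pyrazolyl of compound 3, and the one six-membered ring of carbon only, in compound 2, sits between them. The entering group in compound 4 is again a six-membered ring of carbon only, so a higher number in this assay is expected, of modest size, roughly a 1.9-fold higher number from compound 3 to compound 4 (0.28 log units; within the scatter). Compound 4 is therefore estimated at 13000 nM, with a range from 5000 nM to 35000 nM.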

Compound 4, half-maximal effective concentration: 663 nM
For compound 4 the middle estimate is 20-fold (1.29 log units) above the measured one; the measured number lies below the stated range.
By their numbers in this assay, from the lowest: compound 4; then compound 3; then compounds 2 and 1 (each within the scatter of the next).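

Among these compounds, the position on the aromatic carbon is far more responsive than the earlier compounds showed: in this assay the 3-chloro-5-methylphenyl group gives a 10-fold lower number from compound 3 to compound 4 (1.01 log units; beyond the scatter), along with a 22-fold lower number from compound 2 to compound 4 (1.35 log units; beyond the scatter) and a 32-fold lower number from compound 1 to compound 4 (1.50 log units; beyond the scatter), while the largest earlier step was a 3.1-fold lower number from compound 1 to compound 3 (0.49 log units; beyond the scatter). A six-membered aromatic ring of carbon only is therefore not tied to a higher number, since compound 2 and compound 4 both carry one and differ only in its substituents, 2-methoxy against 3-chloro-5-methyl. No measurement at hand accounts for the size of these steps.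

From the compounds shown here alone, whether the chlorine, the methyl or the two together carry the step remains open. Also open, going by these compounds, is what a nitrile or an amine in their place would do to the number.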